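Extending the sulfanyl chain beyond ethyl on the shared core

This account rests on a few compounds, and the source may have more. Where it says the series, first, only, none or still open, it means among the compounds named here.

Measured compounds:
compound 1, `CSc1nnc(COc2cc(C)c3c(C)cc(=O)oc3c2)o1`: > 100000 nM
compound 2, `CCSc1nnc(COc2cc(C)c3c(C)cc(=O)oc3c2)o1`: > 100000 nM

In a functional assay on MCF7 cells (Homo sapiens) for antiproliferative activity, read by MTT assay, with a stated time of 24 h (a higher number here means a weaker inhibitor, a lower number a stronger inhibitor), compound 1 gives only a limit, > 100000 nM. In this assay compound 2 likewise gives only a limit, > 100000 nM. Both measured values therefore sit at the same limit, as summarised in the limit of > 100000 nM in this assay, at which 2 of the 2 values shown sit, and the step that the two limits leave unreadable from compound 1 to compound 2 cannot be read. Compound 3, `CCCSc1nnc(COc2cc(C)c3c(C)cc(=O)oc3c2)o1`, differs from compound 2 by methyl in place of hydrogen on a saturated chain carbon, two bonds along the chain from a sulfur. For the measured compounds named here, the one measured step that bears on this change, the step from hydrogen to methyl on a saturated chain carbon bound to a sulfur, a step that the two limits leave unreadable from compound 1 to compound 2, gives no size and no direction, so the expectation for this assay rests only on where compound 2 stands. The step that the limit leaves unreadable from compound 2 to compound 3 is expected to be none beyond the scatter, with compound 3 most likely remaining at the limit. Compound 3 is estimated at 150000 nM, within 60000 nM to 400000 nM.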

Compound 3, half-maximal inhibitory concentration: > 100000 nM
Compound 3: no number, only a limit; the forecaster's own chance of this, stated with the estimate: 85%; the middle value does not contradict the limit.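

Compound 3, like compound 1 and compound 2, gives only a limit in this assay, so no step among these three compounds can be read: the limit of > 100000 nM in this assay, at which 3 of the 3 values shown sit.

The compounds shown leave open whether any sulfanyl chain on the shared core brings a measurable value in this cell assay.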